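The source may report more compounds than this note shows. Statements on the series, on what has been measured and on what is new or still open speak of the compounds shown alone.

Compound 2 `COc1ccc(F)cc1CNCCCNc1ccnc2cc(Cc3ccccc3)ccc12` gives 4200 nM in a physicochemical assay for solubility, with a stated time of 18 h, at pH 7.4; on this read-out lower numbers stand for lower solubility and higher numbers for higher solubility. Compound 1 `c1ccc(Cc2ccc3c(NCCCNCc4ccco4)ccnc3c2)cc1` gives 4200 nM and compound 3 `COc1cccc(CNCCCNc2ccnc3cc(Cc4ccccc4)ccc23)c1O` gives 4200 nM in this assay, so compound 2 stands level with both of them; the steps of no change at the digits printed from compound 1 to compound 2 (within the scatter), no change at the digits printed from compound 1 to compound 3 (within the scatter) and no change at the digits printed from compound 2 to compound 3 (within the scatter) all stay within the scatter. Compound 4 `COc1ccc(F)cc1CNCCCNc1ccnc2cc(-c3ccccc3)ccc12` differs from compound 2 in one place: phenyl in place of benzyl on an aromatic carbon. Among the compounds with values here, every measured step swaps the aryl group on the saturated chain carbon bound to an amine nitrogen, and none touches the benzyl on the shared core, so no measured step bears directly on this change. With the three known steps showing no movement, the expected step of no change at the digits printed from compound 2 to compound 4 (within the scatter) is none beyond the scatter. Compound 4 is therefore estimated at 4200 nM, with a range from 1500 nM to 12000 nM.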

Compound 4, solubility: 32000 nM
Compound 4: the middle estimate sits 7.6-fold (0.88 log units) below what was measured; measured number outside the range, above it.
By their numbers in this assay, from the lowest: compounds 1, 2 and 3 (each within the scatter of the next); then compound 4.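

In this assay, within the data shown here, phenyl in place of benzyl on this aromatic carbon gives a 7.6-fold higher number from compound 2 to compound 4 (0.88 log units; beyond the scatter), so this place on the shared core can shift the read-out beyond the scatter, which none of the earlier steps on the saturated chain carbon did. Both groups hold one six-membered aromatic ring of carbon only, and the step comes from this one swap. No measurement shown gives a reason for it.

From the compounds shown here alone, what an amine or a longer chain on this aromatic carbon would give remains open. So does whether the same swap gives a similar step with furan-2-yl or 2-hydroxy-3-methoxyphenyl on the chain.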